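Furan-3-yl in Place of Thiophen-3-yl: An Expected Outcome

The source may hold more compounds than are shown below. What is called first, only, known or untested is meant among the compounds shown, and "the series" means these compounds.

Compound 2 `Oc1cccc(-c2cc(-c3ccsc3)cc(-c3cccc(O)c3)n2)c1` gives 1310 nM in a functional assay on DU-145 cells (Homo sapiens) for cytotoxicity, read by CCK-8 assay (on this read-out higher numbers stand for weaker inhibition and lower numbers for stronger inhibition), the lowest of the two numbers shown there. Compound 3 `Oc1ccc(-c2cc(-c3ccsc3)cc(-c3cccc(O)c3)n2)cc1` gives 2230 nM, and the step of a 1.7-fold higher number from compound 2 to compound 3 (0.23 log units; within the scatter) separates the pair. Compound 1 `Oc1cccc(-c2cc(-c3ccsc3)cc(-c3ccccc3O)n2)c1` reaches only a limit, > 50000 nM (the limit of > 50000 nM in this assay, at which 1 of the 3 values shown sits). Compound 4 `Oc1cccc(-c2cc(-c3ccoc3)cc(-c3cccc(O)c3)n2)c1` differs from compound 2 by furan-3-yl in place of thiophen-3-yl on an aromatic carbon. Going by the values given here, the measured steps of an at least 38-fold lower number from compound 1 to compound 2 (1.58 log units; beyond the scatter) and an at least 22-fold lower number from compound 1 to compound 3 (1.35 log units; beyond the scatter) concern where the hydroxy group sits on the outer rings, not the five-membered ring, so no measured step bears directly on this change. The two rings match in size and shape, so no step beyond the usual scatter is expected in this assay. Compound 4 is therefore estimated at 2000 nM, within 700 nM to 6000 nM, an expected step of a 1.5-fold higher number from compound 2 to compound 4 (0.18 log units; within the scatter).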

Compound 4, half-maximal inhibitory concentration: 1650 nM
For compound 4 the middle estimate is 1.2-fold (0.08 log units) above the measured one; the measured number falls inside the stated range.
By their numbers in this assay, from the lowest: compounds 2, 4 and 3 (each within the scatter of the next). At a limit, above all of these: compound 1.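

In this assay furan-3-yl in place of thiophen-3-yl, opposite the ring nitrogen, gives a 1.3-fold higher number from compound 2 to compound 4 (0.10 log units; within the scatter) and so leaves the two compounds indistinguishable. Going by these compounds alone, the earlier compounds varied only the hydroxy groups, so this is the first sign that this position accepts oxygen in place of sulfur in the five-membered ring. Nothing shown here explains why the two rings read alike. As far as these compounds go, whether an amine, a carboxylic acid or a longer chain such as butyl would fit at this position stays open. So does whether furan-3-yl gives a similar number with the hydroxy groups placed as in compound 3.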